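Chloro added to the benzoyl ring of compound 2

The source may report more compounds than this note shows. Statements on the series, on what has been measured and on what is new or still open speak of the compounds shown alone.

Measured so far:
compound 1, `Nc1scc(-c2cccc(C(F)(F)F)c2)c1C(=O)c1ccccc1`, 83% in a functional assay on CHO cells for agonist activity at adenosine receptor A1 (Homo sapiens), read by fluorescence and ERK phosphorylation, with stated times of 30 min and 1.5 h, tested at 3 uM; a higher number here means a stronger effect of the compound at the concentration tested, a lower number a weaker effect
compound 2, `Nc1scc(-c2ccc3ccccc3c2)c1C(=O)c1ccccc1`, 55% in this assay

Of the compounds shown here, two have been measured. In this assay compound 1 gives 83%. In this assay compound 2 gives 55%, the lower of the two numbers, and the gap to compound 1 lies beyond the usual scatter. Going by the values given here, no step between these two has been worked out, so nothing more is drawn from that pair.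

Compound 3, `Nc1scc(-c2ccc3ccccc3c2)c1C(=O)c1ccc(Cl)cc1`, has not yet been measured. It differs from compound 2 in one place: chloro in place of hydrogen on an aromatic carbon.

Among the compounds with values here, no measured pair shows what such a change does on this core. The expected step from compound 2 to compound 3 in this assay is therefore small and of uncertain direction, no change at the digits printed from compound 2 to compound 3 (within the scatter), likely within the scatter. For compound 3 the estimated value is 55%, expected to fall between 25% and 85%.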

Compound 3, a percentage reported as activity, at one concentration (the size of the read-out at that concentration, not a potency): 54%
Compound 3: middle estimate off by 1 percentage points, on the high side; measured number inside the range.
By their numbers in this assay, from the lowest: compounds 3 and 2 (each within the scatter of the next); then compound 1.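

In this assay, chloro in place of hydrogen on an aromatic carbon, the change from phenyl to 4-chlorophenyl, gives a number 1 percentage points lower from compound 2 to compound 3 (within the scatter). Going by these compounds alone, this is the first step measured on the shared core, and it shows that this one added chlorine atom, with the rest of compound 2 kept, leaves the read-out at the tested concentration within the scatter, so this position tolerates chloro in this assay. Nothing available offers an explanation for this result.

From the compounds shown here alone, whether an amine, a methoxy group or a carboxylic acid at the same position would also leave the read-out within the scatter stays open. So does whether the same chloro step would read alike on the core of compound 1, and, as only one concentration is reported, whether the effect would stay alike at other concentrations.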